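A piperazine added to the pyridine of compound 2

A few compounds are considered here, and "the series" means these few. Any claim that something is new, unique, unknown or untested is made for them only; others in the source may bear on it.

Measured in a functional assay on MDA-MB-231 cells (Homo sapiens) for inhibition, read by CCK-8 assay, with a stated time of 48 h; a higher number here means a weaker inhibitor of growth, a lower number a stronger inhibitor of growth:
Compound 1 `Cc1ccccc1Nc1nc(NC2CC2)ncc1Cl`: > 100000 nM (a limit of the assay, not a number)
Compound 2 `Cc1ccccc1Nc1nc(Nc2ccccn2)ncc1Cl`: 11200 nM

Among the measured compounds shown here, compound 2 holds the only true number so far, at 11200 nM. The result for compound 1 is a limit of the assay (the limit of > 100000 nM in this assay, at which 1 of the 2 values shown sits). Compound 3 `Cc1ccccc1Nc1nc(Nc2ccc(N3CCNCC3)cn2)ncc1Cl` has piperazin-1-yl in place of hydrogen on an aromatic carbon, two atoms from the ring nitrogen and para to a large group (piperazin-1-yl in place of hydrogen on an aromatic carbon). For the measured compounds named here, the one measured step, an at least 8.9-fold lower number from compound 1 to compound 2 (0.95 log units; beyond the scatter), lies beyond the scatter and brought in this pyridin-2-yl ring, in place of cyclopropyl. That step says nothing directly about a group added to the ring, so only a moderate move is expected in this assay, toward a lower number. The expected change is a 4.5-fold lower number from compound 2 to compound 3 (0.65 log units; beyond the scatter). For compound 3 the estimated value is 2500 nM, with an expected range of 400 nM to 12000 nM.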

Compound 3, concentration for 50% growth inhibition: 5060 nM
Compound 3: middle estimate off by 2.0-fold (0.31 log units), on the low side, and the stated range covers the measured number.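

The earlier compounds shown here showed only a change on the nitrogen that carries the pyridine. Among the compounds shown here, compound 3 is the first to show that the pyridine ring itself can take a substituent, at the carbon two atoms from the ring nitrogen and para to a large group. In this assay, a piperazin-1-yl group there is tolerated and gives a modest gain, with a 2.2-fold lower number from compound 2 to compound 3 (0.35 log units; beyond the scatter). For the compounds shown here, nothing measured so far accounts for the size or direction of this step.

As far as these compounds go, it remains open whether the gain depends on the piperazine's hydrogen-bearing nitrogen, which a morpholine or an N-methylpiperazine at the same carbon would test. From the compounds shown here alone, it is also open whether a smaller amine, such as dimethylamino, would serve as well as the whole ring.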